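Swapping one bicyclic ring for another on a urea nitrogen

The source may hold more compounds than are shown below. What is called first, only, known or untested is meant among the compounds shown, and "the series" means these compounds.

In an assay on CHO cells for antagonist activity at transient receptor potential cation channel subfamily V member 1 (Homo sapiens), read by scintillation counting, with a stated time of 5 min, in the presence of a further agent that is not named here (a higher number here means that more compound is needed for the effect, a lower number that less compound is needed), compound 1 `CN(C)C1(Cc2ccccc2)CCN(c2cc(C(F)(F)F)ccc2CNC(=O)Nc2ccc(CO)c(F)c2)CC1` gives 81 nM. Among the measured compounds shown here, compound 2 `CN(C)C1(Cc2ccccc2)CCN(c2cc(C(F)(F)F)ccc2CNC(=O)Nc2cccc3c(=O)[nH]ccc23)CC1` shares the core of compound 1 but carries a different bicyclic group on the urea nitrogen, and in this assay compound 2 is reported as "not active" (no number reported), so no single number stands for it, and no step between compound 2 and compound 1 can be given beyond that contrast. Compound 3 `CN(C)C1(Cc2ccccc2)CCN(c2cc(C(F)(F)F)ccc2CNC(=O)Nc2ccc3cnccc3c2)CC1` differs from compound 2 by a group of 10 heavy atoms (9 carbon, 1 nitrogen; one six-membered aromatic ring of carbon only, one six-membered aromatic ring with 1 hetero atom) in place of a group of 11 heavy atoms (9 carbon, 1 nitrogen, 1 oxygen; one six-membered aromatic ring of carbon only, one six-membered aromatic ring with 1 hetero atom), on an amide-type nitrogen, that is, a group of 10 heavy atoms (9 carbon, 1 nitrogen; one six-membered aromatic ring of carbon only, one six-membered aromatic ring with 1 hetero atom) in place of a group of 11 heavy atoms (9 carbon, 1 nitrogen, 1 oxygen; one six-membered aromatic ring of carbon only, one six-membered aromatic ring with 1 hetero atom), on an amide-type nitrogen. With compound 2 lacking a number, the size of this step cannot be measured here; the expectation is that compound 3 regains a readable value in this assay, though weaker than compound 1. Compound 3 is estimated at 500 nM, within a range from 100 nM to 5000 nM.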

Compound 3, half-maximal effective concentration: 156 nM
Beside the measured number, compound 3's estimate is 3.2-fold (0.51 log units) above it; measured number inside the range.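

In this assay, a 1.9-fold higher number from compound 1 to compound 3 (0.28 log units; within the scatter) shows that on this amide-type nitrogen, isoquinolin-6-yl and 3-fluoro-4-(hydroxymethyl)phenyl cannot be told apart, even though one group has two rings and the other has one. The group in compound 2 also has one six-membered aromatic ring of carbon only and one with 1 hetero atom, yet compound 2 is reported as not active while compound 3 gives a readable value, so this ring count alone does not decide the outcome; with no number for compound 2, however, the size of that step cannot be read. No measurement at hand explains this contrast between compound 2 and compound 3.

The compounds shown leave open which difference between these two bicyclic groups separates compound 2 from compound 3, since the groups differ in more than one feature, including the carbonyl and the hydrogen-bond donor present only in the group of compound 2. They also leave open whether the ring nitrogen of isoquinolin-6-yl is needed, a question that naphthalen-2-yl, built of carbon alone, could answer at this position.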